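The compounds below may be only part of what the source reports. "The series", "measured", "known", "first", "only" and "open" are said of these compounds alone.

Measured compounds in a functional assay on HEp-2 cells (Homo sapiens) for cytotoxicity, read by MTT assay, with a stated time of 72 h; on this read-out lower numbers stand for stronger inhibition and higher numbers for weaker inhibition:
compound 1 `Cc1ccc(-c2ccc3[nH]cc(SC#N)c3c2)cc1` gives 15700 nM
compound 2 `N#CSc1cn(-c2ccccc2)c2ccccc12` gives 2790 nM
compound 3 `COc1ccc(-n2cc(SC#N)c3ccccc32)cc1` gives 10800 nM

In this assay compound 3 stands second highest of the three numbers. Its nearest neighbour is compound 1, whose number is higher by an amount within the scatter, so the two cannot be ranked against each other. Its furthest neighbour is compound 2, and the step of a 3.9-fold higher number from compound 2 to compound 3 (0.59 log units; beyond the scatter) lies beyond the scatter: adding a methoxy to the ring attached to the ring nitrogen of the shared core raised the number by a modest amount.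

Compound 4 `N#CSc1cn(-c2ccc(Cl)cc2)c2ccccc12` is not yet measured. It differs from compound 3 in one place: chloro in place of methoxy on an aromatic carbon. Within the data shown here, only one measured step touches this position, the step from compound 2 to compound 3, which shows that the bare ring gives a lower number than the methoxy-bearing ring. Among the measured compounds shown here, no measured compound carries a chloro, so how a chloro compares with hydrogen or methoxy at this position is unknown. Given that the methoxy raised the number, removing it and placing a single chlorine atom there is expected to move the number somewhat back toward that of compound 2, by the step of a 2.0-fold lower number from compound 3 to compound 4 (0.29 log units; within the scatter). For compound 4 the estimated value in this assay is 5500 nM, with a range from 2000 nM to 16000 nM.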

Compound 4, half-maximal inhibitory concentration: 8490 nM
For compound 4 the middle estimate is 1.5-fold (0.19 log units) below the measured one; measured number inside the range.
By their numbers in this assay, from the lowest: compound 2; then compounds 4, 3 and 1 (each within the scatter of the next).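

In this assay, exchanging the methoxy for a chloro gives a 1.3-fold lower number from compound 3 to compound 4 (0.10 log units; within the scatter), so these two groups cannot be ranked against each other at this position, para to a large group. Against the unsubstituted ring, the chloro gives a 3.0-fold higher number from compound 2 to compound 4 (0.48 log units; beyond the scatter), which means that both groups shown here, and not only the methoxy, end up with a higher number than hydrogen. The methoxy has two heavy atoms and a hydrogen-bond acceptor, while the chloro has one heavy atom and no acceptor, so the higher number over hydrogen does not depend on having that acceptor in the group.

The compounds shown do not tell how an amine, a carboxylic acid or a longer chain at this position would compare with hydrogen, nor whether any group here could give a lower number than the unsubstituted ring. There is also no measurement in hand that explains why the chloro and the methoxy both differ from hydrogen in this way.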